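A few compounds are considered here, and "the series" means these few. Any claim that something is new, unique, unknown or untested is made for them only; others in the source may bear on it.

Of the compounds shown here, three have so far been tested for their ability to hold back the growth of a human ovarian cancer cell line. Compound 1, `COc1cc(-c2cc(/C=C/C(=O)c3ccc(N)cc3)[nH]n2)cc(OC)c1OC`, compound 3, `COc1ccc(-c2cc(/C=C/C(=O)c3ccc(N)cc3)[nH]n2)cc1OC`, and compound 2, `COc1ccc(C(=O)/C=C/c2cc(-c3cc(OC)c(OC)c(OC)c3)n[nH]2)cc1OC`, all carry methoxy-bearing aromatic rings at both ends of a shared core. In a functional assay on OVCAR-8 cells (Homo sapiens) for inhibition, read by sulforhodamine B assay, with a stated time of 48 h (a lower number here means a stronger inhibitor of growth, a higher number a weaker inhibitor of growth), compound 1 gives 9760 nM. In this assay compound 3 gives 10500 nM. In this assay compound 2 gives 2730 nM, the lowest of the three numbers.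

Two single changes link these measurements. From compound 3 to compound 1 the change is methoxy in place of hydrogen on an aromatic carbon, and it made a 1.1-fold lower number from compound 3 to compound 1 (0.03 log units; within the scatter). From compound 1 to compound 2 the change is a 3,4-dimethoxyphenyl in place of a 4-aminophenyl on the carbonyl carbon, which gave a 3.6-fold lower number from compound 1 to compound 2 (0.55 log units; beyond the scatter). How the core of compound 2 differs from that of compound 3 is not broken down here.

Compound 4, `COc1cc(C(=O)/C=C/c2cc(-c3cc(OC)c(OC)c(OC)c3)n[nH]2)cc(OC)c1OC`, is not yet measured. It differs from compound 2 by methoxy in place of hydrogen on an aromatic carbon, the same change that was made from compound 3 to compound 1. Because that earlier step, a 1.1-fold lower number from compound 3 to compound 1 (0.03 log units; within the scatter), stayed within the usual scatter, a step of about a 1.1-fold lower number from compound 2 to compound 4 (0.04 log units; within the scatter) from compound 2 to compound 4 in this assay is expected. Compound 4 is therefore estimated at 2500 nM, with a likely range from 1200 nM to 5500 nM.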

Compound 4, concentration for total growth inhibition: 3280 nM
The estimate for compound 4 lay 1.3-fold (0.12 log units) below the measured number; measured number inside the range.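

In this assay, putting a methoxy group in place of hydrogen on an aromatic carbon of compound 2 gave a 1.2-fold higher number from compound 2 to compound 4 (0.08 log units; within the scatter), so this step cannot be told apart from no change at all. Set beside the earlier case, the same change reads alike on the two cores, with neither step showing a real effect on the number: the same change on two cores in this assay, a 1.1-fold lower number (0.03 log units; within the scatter) from compound 3 to compound 1 and a 1.2-fold higher number (0.08 log units; within the scatter) from compound 2 to compound 4, 1.3-fold (0.11 log units) apart, within the scatter of two such steps

This supports a modest conclusion: on these two cores, in this one assay on a single cell line, the extra methoxy neither clearly helped nor clearly hurt, and a near-zero step seen on one core was a fair guide to the other. It does not show that the change would stay silent on a different core or in a different test, and two steps of this size say nothing about why the number holds still.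

The compounds shown leave open whether any group other than methoxy at this place, such as a hydroxyl, a chlorine atom or a longer ethoxy chain, would shift the number beyond the scatter. They also leave open whether a carboxylic acid there would be accepted, so the tolerance seen so far applies to methoxy alone.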